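This account rests on a few compounds, and the source may have more. Where it says the series, first, only, none or still open, it means among the compounds named here.

Compound 2 `CC1=C(C(=O)OCC(C)O[N+](=O)[O-])C(c2cccc3nonc23)C([N+](=O)[O-])=C(C)C1` and compound 1 `CC1=C(C(=O)OCCO[N+](=O)[O-])[C@@H](c2cccc3nonc23)C([N+](=O)[O-])=C(C)C1` share the same core and differ only in the chain attached on an oxygen next to a carbonyl group. In a functional assay (ileum) for antagonist activity, with Cavia porcellus as the target (on this read-out higher numbers stand for weaker inhibition and lower numbers for stronger inhibition), compound 2 gives 1700 nM, the highest number among the two measured compounds, while compound 1 gives 115 nM in this assay, a far lower number; compound 2 is thus the weaker inhibitor of the pair. Compound 3 `CC1=C(C(=O)OC(C)CO[N+](=O)[O-])C(c2cccc3nonc23)C([N+](=O)[O-])=C(C)C1` keeps every atom of compound 2 but joins them differently: a group of 7 heavy atoms (3 carbon, 1 nitrogen, 3 oxygen; no ring) in place of a group of 7 heavy atoms (3 carbon, 1 nitrogen, 3 oxygen; no ring), on an oxygen next to a carbonyl group. For the measured compounds named here, no measured pair in this set shows a change of this kind, so there is no measured step to lean on. A rearrangement of the same atoms within one chain is expected to move the number only moderately, most likely downward, since compound 1 shows with 115 nM that a differently built chain at this oxygen can give a much stronger inhibition. The expected step is a 1.7-fold lower number from compound 2 to compound 3 (0.23 log units; within the scatter). Compound 3 is therefore estimated to give about 1000 nM in this assay, within a range from 300 nM to 4000 nM.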

Compound 3, half-maximal inhibitory concentration: 6380 nM
Compound 3: middle estimate off by 6.4-fold (0.80 log units), on the low side, outside the stated range (above it).
By their numbers in this assay, from the lowest: compound 1; then compound 2; then compound 3.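

In this assay, this position proves sensitive to how the chain is joined and not only to what it contains: with the same atoms on an oxygen next to a carbonyl group, the result is a 3.8-fold higher number from compound 2 to compound 3 (0.57 log units; beyond the scatter). The two chains have identical computed counts, so those counts cannot separate them, and the step, though modest, is beyond the scatter and points towards weaker inhibition, which means that this rearrangement moves the number away from that of compound 1, at 115 nM, rather than towards it. Nothing in the available data explains why the two arrangements differ.

The compounds shown leave open whether a longer chain at this oxygen, or a chain carrying an amine or a carboxylic acid, would give a lower or a higher number than these three compounds. With only this one rearrangement to read, they also leave open whether joining the same atoms differently would change the number in the same direction and by a similar size in any other chain.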